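The source may hold more compounds than are shown below. What is called first, only, known or untested is meant among the compounds shown, and "the series" means these compounds.

Three compounds share one core and differ only in the group on an amine nitrogen. Compound 1 `Cc1c(Cc2ccccc2)c(=O)oc2cc(OCC(O)CNc3cc([N+](=O)[O-])ccc3O)ccc12` carries a 2-hydroxy-5-nitrophenyl there; in an ADME assay on A549 cells (Homo sapiens) for cytotoxicity, read by CellTiter-Glo (on this read-out higher numbers stand for lower toxicity in this test and lower numbers for higher toxicity in this test), compound 1 gives > 100000 nM, which is a limit of the test rather than a number. Compound 2 `Cc1c(Cc2ccccc2)c(=O)oc2cc(OCC(O)CNCc3ccccc3)ccc12` carries a benzyl; in this assay compound 2 gives > 100000 nM, again a limit. For the measured compounds named here, compound 3 `Cc1c(Cc2ccccc2)c(=O)oc2cc(OCC(O)CNC3CCOCC3)ccc12` carries an oxan-4-yl and is the only one with an actual number, 38200 nM. The steps read an at least 2.6-fold lower number from compound 1 to compound 3 (0.41 log units; beyond the scatter) and an at least 2.6-fold lower number from compound 2 to compound 3 (0.41 log units; beyond the scatter), while a step that the two limits leave unreadable from compound 1 to compound 2. Compound 4 `Cc1c(Cc2ccccc2)c(=O)oc2cc(OCC(O)CNCc3cccs3)ccc12` brings ((thiophen-2-yl)methyl in place of oxan-4-yl on an amine nitrogen). Because compound 2, whose methyl also bears a ring, sits at the limit of > 100000 nM in this assay, at which 2 of the 3 values shown sit, compound 4 is expected to move back up, a step of a 2.1-fold higher number from compound 3 to compound 4 (0.32 log units; beyond the scatter). The estimate for compound 4 is 80000 nM, between 30000 nM and 200000 nM.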

Compound 4, half-maximal cytotoxic concentration: 87300 nM
Compound 4: middle estimate off by 1.1-fold (0.04 log units), on the low side, within the range that was stated.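

For the compounds shown here, putting (thiophen-2-yl)methyl in place of oxan-4-yl on this amine nitrogen gives the first step here with a real number at both ends (a 2.3-fold higher number from compound 3 to compound 4 (0.36 log units; beyond the scatter)). The steps that start from the two limits are looser: one is an at least 1.1-fold lower number from compound 2 to compound 4 (0.05 log units; that floor lies within the scatter) and the other is an at least 1.1-fold lower number from compound 1 to compound 4 (0.05 log units; that floor lies within the scatter). Neither floor shows a real change, and the limits still dominate this small set: the limit of > 100000 nM in this assay, at which 2 of the 4 values shown sit.

Still open, from the compounds shown here alone, is how a (furan-2-yl)methyl or a 2-phenylethyl group on this nitrogen would read. Also open, going by these compounds, is how far compound 1 and compound 2 actually lie past their limits.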